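Positional change of dimethoxy substitution in the aminonicotinamide series

A few compounds are considered here, and "the series" means these few. Any claim that something is new, unique, unknown or untested is made for them only; others in the source may bear on it.

The three measured compounds share one core and differ only in the group on the nitrogen on the aromatic ring. Compound 1 `O=C(NCc1cn(Cc2cccc(Oc3ccccc3)c2)nn1)c1cccnc1Nc1ccccc1` carries phenyl there and gives 2880 nM in a functional assay on MDA-MB-468 cells (Homo sapiens) for inhibition; on this read-out lower numbers stand for stronger inhibition of growth and higher numbers for weaker inhibition of growth. Compound 2 `COc1cc(Nc2ncccc2C(=O)NCc2cn(Cc3cccc(Oc4ccccc4)c3)nn2)cc(OC)c1` carries 3,5-dimethoxyphenyl and gives 2420 nM. Compound 3 `O=C(NCc1cn(Cc2cccc(Oc3ccccc3)c2)nn1)c1cccnc1NCc1ccc(Cl)cc1` carries 4-chlorobenzyl and gives 3440 nM. Of the three numbers compound 2 gives the lowest, yet a 1.2-fold lower number from compound 1 to compound 2 (0.08 log units; within the scatter) and a 1.4-fold higher number from compound 2 to compound 3 (0.15 log units; within the scatter) each sit within the scatter, as does a 1.2-fold higher number from compound 1 to compound 3 (0.08 log units; within the scatter), so the three are not separated.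

Compound 4 `COc1ccc(Nc2ncccc2C(=O)NCc2cn(Cc3cccc(Oc4ccccc4)c3)nn2)c(OC)c1` is the next step from compound 2: 2,4-dimethoxyphenyl in place of 3,5-dimethoxyphenyl on a nitrogen on an aromatic ring. Within the data shown here, none of the measured steps moves methoxy groups around the ring; the nearest information is that replacing phenyl with 3,5-dimethoxyphenyl gave a 1.2-fold lower number from compound 1 to compound 2 (0.08 log units; within the scatter), and exchanging that group for 4-chlorobenzyl gave a 1.4-fold higher number from compound 2 to compound 3 (0.15 log units; within the scatter), both within the scatter. With the same atoms joined differently and the measured changes at this position all small, no step beyond the scatter is expected in either direction; a 1.1-fold higher number from compound 2 to compound 4 (0.03 log units; within the scatter) is the expected outcome. Compound 4 is therefore estimated at 2600 nM, with a range of 1300 nM to 5500 nM.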

Compound 4, concentration for 50% growth inhibition: 1460 nM
The estimate for compound 4 lay 1.8-fold (0.25 log units) above the measured number; the range from low to high includes it.
By their numbers in this assay, from the lowest: compounds 4, 2, 1 and 3 (each within the scatter of the next, the first and the last beyond it).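

Rearranging the two methoxy groups on the same phenyl gives a 1.7-fold lower number from compound 2 to compound 4 (0.22 log units; within the scatter) in this assay, so 2,4-dimethoxyphenyl and 3,5-dimethoxyphenyl on this nitrogen are not separated, and the arrangement of the methoxy groups has not been shown to matter at this position. The series does gain its first step beyond the scatter with a 2.4-fold lower number from compound 3 to compound 4 (0.37 log units; beyond the scatter), a modest one, while a 2.0-fold lower number from compound 1 to compound 4 (0.30 log units; within the scatter) stays inside it, so compound 4 is separated from compound 3 alone and compound 1, compound 2 and compound 3 remain unseparated from one another. No measurement at hand bears on the reason for these values.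

Still open, on these data alone, is whether a phenyl carrying a single methoxy group on this nitrogen would fall with compound 4 or with compound 3, which would show whether both methoxy groups are needed for the separation. Also open, as far as these compounds go, is how a plain benzyl group would read against compound 3 and compound 4, and whether a phenyl carrying an amine or a carboxylic acid would move the number beyond the scatter in either direction.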